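Series notes: trifluoromethoxy for trifluoromethyl on compound 3

The source may report more compounds than this note shows. Statements on the series, on what has been measured and on what is new or still open speak of the compounds shown alone.

Compound 3 `Cc1cc(=O)n(-c2ccccc2C(F)(F)F)nc1C(=O)Nc1ccc(Oc2ncnc3ccsc23)cc1` gives 9230 nM in a functional assay on HepG2 cells (Homo sapiens) for cytotoxicity, read by MTT assay, with a stated time of 72 h (a higher number here means a weaker inhibitor, a lower number a stronger inhibitor), the second highest of the three numbers; compound 2 `CNC(=O)c1cc(Oc2ccc(NC(=O)c3nn(-c4ccc(C)cc4)c(=O)cc3C)cc2F)ccn1` at 10600 nM sits within the scatter of it, while compound 1 `CNC(=O)c1cc(Oc2ccc(NC(=O)c3nn(-c4ccc(Br)cc4F)c(=O)cc3C)cc2F)ccn1` at 2830 nM lies beyond the scatter below it. Compound 4 `Cc1cc(=O)n(-c2ccccc2OC(F)(F)F)nc1C(=O)Nc1ccc(Oc2ncnc3ccsc23)cc1` differs from compound 3 only by trifluoromethoxy in place of trifluoromethyl on an aromatic carbon. Among the compounds with values here, the one step measured on the aryl attached to the ring nitrogen, a 3.7-fold higher number from compound 1 to compound 2 (0.57 log units; beyond the scatter), exchanges the whole substitution pattern rather than one group, so it bears only loosely on this change. Within the data shown here, no measured pair shows this particular swap, so a step within the scatter is expected, a 1.2-fold lower number from compound 3 to compound 4 (0.06 log units; within the scatter). Compound 4 is therefore estimated at 8000 nM in this assay, with a range from 2500 nM to 25000 nM.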

Compound 4, half-maximal inhibitory concentration: 25000 nM
Compound 4: middle estimate off by 3.1-fold (0.49 log units), on the low side, within the range that was stated.
By their numbers in this assay, from the lowest: compound 1; then compounds 3 and 2 (each within the scatter of the next); then compound 4.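

In this assay, within the data shown here, the single exchange on this aromatic carbon gives a 2.7-fold higher number from compound 3 to compound 4 (0.43 log units; beyond the scatter), so this place responds to one group alone, whereas the earlier step changed a whole substitution pattern on a different core. The change leads to a weaker inhibitor here. No measured evidence accounts for this step. Open, on these data alone, is whether an amine, a methoxy group or a carboxylic acid at this place would give a number nearer compound 3 or compound 4, and whether the same exchange would give a similar step on the core of compound 1.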